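The source may hold more compounds than are shown below. What is called first, only, known or untested is meant among the compounds shown, and "the series" means these compounds.

Compound 1 `COc1ccc(-c2nc(SCC(=O)c3sc(-c4ccccc4)nc3C)[nH]c(=O)c2C#N)cc1`: 90.4%
Compound 2 `COc1ccc(-c2nc(C)c(C(=O)CSc3nc(-c4ccc(OC)cc4)c(C#N)c(=O)[nH]3)s2)cc1`: 80.3%

Both were tested in a functional assay on U-87MG ATCC cells for antiproliferative activity against U-87 MG (Homo sapiens), read by MTT assay, with a stated time of 48 h, tested at 10 uM; a lower number here means a stronger effect, a higher number a weaker effect of the compound at the concentration tested. Among the compounds with values here, compound 2 has the lower of the two numbers, and the single measured step, a number 10.1 percentage points lower from compound 1 to compound 2 (beyond the scatter), is a modest one. Compound 3 `COc1ccc(-c2nc(C)c(C(=O)CSc3nc(-c4ccc(Cl)c(Cl)c4)c(C#N)c(=O)[nH]3)s2)cc1` has not yet been measured. It differs from compound 2 by 3,4-dichlorophenyl in place of 4-methoxyphenyl on an aromatic carbon. Within the data shown here, no measured step touches that part of the molecule: the only known step concerns a methoxy in place of hydrogen on an aromatic carbon elsewhere, and it moved the read-out only modestly. There is thus little ground for expecting a large shift in this assay in either direction, and a step not clearly beyond the usual scatter is anticipated. In this assay compound 3 is expected to give about 78%, within a range of 62% to 94%. This corresponds to an expected step of a number 2.3 percentage points lower from compound 2 to compound 3 (within the scatter).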

Compound 3, a percentage reported as activity, at one concentration (the size of the read-out at that concentration, not a potency): 88.6%
Compound 3: the middle estimate sits 10.6 percentage points below what was measured; measured number inside the range.
By their numbers in this assay, from the lowest: compounds 2, 3 and 1 (each within the scatter of the next, the first and the last beyond it).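

In this assay, the exchange of 4-methoxyphenyl for 3,4-dichlorophenyl on the aromatic carbon ortho to the cyano group gives a number 8.3 percentage points higher from compound 2 to compound 3 (within the scatter). Within the data shown here, this is the first view of this position, since compound 1 and compound 2 both carry 4-methoxyphenyl there, and it shows that these two aryl groups cannot be told apart at the single concentration tested. Nothing available explains this outcome or bears on it.

Open, as far as these compounds go, is whether an unsubstituted phenyl, or a phenyl carrying an amine or a carboxylic acid, would also stay within the scatter at this position. Also open, from the compounds shown here alone, is whether the methoxy step seen between compound 1 and compound 2 at the other end of the molecule would recur with 3,4-dichlorophenyl in place.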